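Two limits and a methoxy swap

This account rests on a few compounds, and the source may have more. Where it says the series, first, only, none or still open, it means among the compounds named here.

Measured so far in a physicochemical assay for solubility, measured as kinetic solubility; a higher number here means a more soluble compound, a lower number a less soluble compound
compound 1 `CNC(=O)c1cc(C(=O)N[C@H]2CC[C@H](O)CC2)c([C@@H](C)c2cccc(Cl)c2)o1` gives >= 179 ug/mL (a limit)
compound 2 `CNC(=O)c1cc(C(=O)N[C@H]2CC[C@H](O)CC2)c([C@@H](C)c2cccc(F)c2)o1` gives >= 63 ug/mL (a limit)

Compound 2 stands at >= 63 ug/mL as a limit of the assay, not a number. Compound 3 `CNC(=O)c1cc(C(=O)N[C@H]2CC[C@H](O)CC2)c([C@@H](C)c2cccc(OC)c2)o1` carries methoxy in place of fluoro on an aromatic carbon and awaits measurement. For the measured compounds named here, the only measured step is a step that the two limits leave unreadable from compound 1 to compound 2 and so offers no size to carry over. With no readable step to go on, no change beyond the scatter is expected in this assay for this swap. The expected step is a step that the limit leaves unreadable from compound 2 to compound 3 on this estimate. Compound 3 is estimated at 110 ug/mL with 45 ug/mL to 250 ug/mL as its expected range.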

Compound 3, solubility: >= 113 ug/mL
Compound 3 ended at the assay's limit; the forecaster's own chance of this, stated with the estimate: 55%; middle value at least 1.0-fold (0.01 log units) away from the limit.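

In this assay, for the compounds shown here, compound 1, compound 2 and compound 3 all stand at limits, not numbers, and no step among them can be read. Going by these compounds, how far the chloro, fluoro and methoxy compounds actually differ remains open.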